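This account rests on a few compounds, and the source may have more. Where it says the series, first, only, none or still open, it means among the compounds named here.

Of the compounds shown here, two built on a shared core have been measured. Compound 1 `Clc1ccc(-c2csc(N/N=C/c3cccs3)n2)cc1` in a functional assay, read by spectrophotometry, with a stated time of 15 min, tested at 40 ug/mL (a lower number here means a weaker effect, a higher number a stronger effect of the compound at the concentration tested), gives 96%. Compound 2 `Cc1ccc(-c2csc(N/N=C/c3ccc(Cl)cc3Cl)n2)cc1` in this assay gives 86.2%, a number that lies within the usual scatter of the value of compound 1, so the two cannot be told apart. Compound 3 `Clc1ccc(/C=N/Nc2nc(-c3ccccc3)cs2)c(Cl)c1` has not yet been measured. It differs from compound 2 in one place: hydrogen in place of methyl on an aromatic carbon. Within the data shown here, no measured pair shows this change, so its effect is unknown; the expected step from compound 2 to compound 3 in this assay is small, a number 0.8 percentage points higher from compound 2 to compound 3 (within the scatter), with no direction beyond the scatter. Compound 3 is estimated at 87%, with a range from 70% to 97%.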

Compound 3, a percentage reported as inhibition, at one concentration (the size of the read-out at that concentration, not a potency): 90.2%
Beside the measured number, compound 3's estimate is 3.2 percentage points below it, and the stated range covers the measured number.
By their numbers in this assay, from the lowest: compounds 2, 3 and 1 (each within the scatter of the next).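

Among these compounds, the first measured pair for hydrogen in place of methyl gives, in this assay, a number 4 percentage points higher from compound 2 to compound 3 (within the scatter), so compound 2 and compound 3 cannot be told apart. At this aromatic carbon, para to a large group, the methyl is therefore not needed to keep the read-out at this concentration. Nothing available gives a reason for this result.

As far as these compounds go, whether an amine, a carboxylic acid or a longer chain at this position would leave the read-out as it stands remains open. This single pair also cannot show whether the same change behaves alike on other compounds.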